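This account rests on a few compounds, and the source may have more. Where it says the series, first, only, none or still open, it means among the compounds named here.

Measured compounds: compound 1 `CN(C)c1ccc(C(=O)N2CCC(NS(=O)(=O)c3cc(S(=O)(=O)c4ccccc4)ccc3C(F)(F)F)CC2)cc1` gives 190 nM in an assay on U2OS cells for inhibition of secreted frizzled-related protein 1 (Homo sapiens), read by a luciferase reporter, with a stated time of 18 h; on this read-out lower numbers stand for an effect already at smaller amounts and higher numbers for an effect only at larger amounts of compound; compound 2 `CC(C)(C)OC(=O)N1CCC[C@H]1C(=O)N1CCC(NS(=O)(=O)c2cc(S(=O)(=O)c3ccccc3)ccc2C(F)(F)F)CC1` gives 60 nM in this assay.

Compound 2 stands at the lowest of the two numbers, the only one beyond the scatter from compound 1. Compound 3 `O=C([C@H]1CCNC1)N1CCC(NS(=O)(=O)c2cc(S(=O)(=O)c3ccccc3)ccc2C(F)(F)F)CC1` differs from compound 2 in one place: pyrrolidin-3-yl in place of 1-(tert-butoxycarbonyl)pyrrolidin-2-yl on a carbonyl carbon. Among the compounds with values here, the single measured step, a 3.2-fold lower number from compound 1 to compound 2 (0.50 log units; beyond the scatter), concerns the same carbonyl carbon but a different exchange, so it bears on the new step only loosely. Lacking a direct comparison, compound 3 is expected to move modestly back towards the higher number, roughly a 2.5-fold higher number from compound 2 to compound 3 (0.40 log units; beyond the scatter). Compound 3 is estimated at 150 nM, within a range of 40 nM to 600 nM.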

Compound 3, half-maximal effective concentration: 700 nM
For compound 3 the middle estimate is 4.7-fold (0.67 log units) below the measured one; measured number outside the range, above it.
By their numbers in this assay, from the lowest: compound 2; then compound 1; then compound 3.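

In this assay, within the data shown here, the position on the carbonyl carbon proves more sensitive than the earlier step showed: pyrrolidin-3-yl in place of 1-(tert-butoxycarbonyl)pyrrolidin-2-yl brings a 12-fold higher number from compound 2 to compound 3 (1.07 log units; beyond the scatter) and is the largest step so far. Pyrrolidin-3-yl in place of 4-(dimethylamino)phenyl brings a 3.7-fold higher number from compound 1 to compound 3 (0.57 log units; beyond the scatter) and so runs opposite to the first exchange at this carbon. Nothing measured here accounts for these shifts.

This exchange drops the tert-butoxycarbonyl group and changes the ring attachment together, and the compounds shown cannot separate the two. A plain pyrrolidin-2-yl or a 1-(tert-butoxycarbonyl)pyrrolidin-3-yl group would be needed to tell them apart.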